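A few compounds are considered here, and "the series" means these few. Any claim that something is new, unique, unknown or untested is made for them only; others in the source may bear on it.

- Compound 1 `CC(C)CN(C1CCc2ccc(F)cc21)S(=O)(=O)c1ccc2c(c1)C(=O)CC(C1CCOCC1)O2`: 4.03
- Compound 2 `CCc1ccc(N(CC(C)C)S(=O)(=O)c2ccc(OCC3CCOCC3)c3c2CCCC3=O)cc1`: 4.84
- Compound 3 `CCc1ccc(NS(=O)(=O)c2ccc3c(c2)C(=O)CC(C2CCOCC2)O3)cc1`: 2.67

In a physicochemical assay for lipophilicity, at pH 7.4 (on this read-out lower numbers stand for lower lipophilicity and higher numbers for higher lipophilicity), compound 1 stands second highest of the three at 4.03, below compound 2 and above compound 3, with both gaps beyond the scatter. Compound 4 `CC(C)CN(c1ccc(F)cc1F)S(=O)(=O)c1ccc2c(c1)C(=O)CC(C1CCOCC1)O2` departs from compound 1 in one place: 2,4-difluorophenyl in place of 6-fluoro-2,3-dihydro-1H-inden-1-yl on a sulfonamide nitrogen. In words, 2,4-difluorophenyl takes the place of 6-fluoro-2,3-dihydro-1H-inden-1-yl on a sulfonamide nitrogen. Going by the values given here, no measured pair of compounds differs in this way, so the expectation has no direct precedent. A slight downward move is expected, and the estimated step of a number 0.13 log units lower from compound 1 to compound 4 (within the scatter) would stay within the scatter. For compound 4 the expected value is 3.9, with an estimated range of 3.5 to 4.3.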

Compound 4, distribution coefficient: 3.62
For compound 4 the middle estimate is 0.28 log units above the measured one, and the stated range covers the measured number.
By their numbers in this assay, from the lowest: compound 3; then compound 4; then compound 1; then compound 2.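

In this assay, going by these compounds alone, the change to 2,4-difluorophenyl in place of 6-fluoro-2,3-dihydro-1H-inden-1-yl on a sulfonamide nitrogen gives a number 0.41 log units lower from compound 1 to compound 4 (beyond the scatter) and is the only single-place step available, showing that the read-out responds to this position. The entering group has fewer heavy atoms and one ring fewer than the leaving group, and this one pair cannot separate those differences. Nothing measured here explains the step. Still open, on these data alone, is how a plain phenyl or a cyclohexyl group on the same nitrogen would compare, and whether the step would hold with another group in place of the saturated chain on that nitrogen.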